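From Fluoro to Chloro: Expecting the Next Growth Inhibition Value

The compounds below may be only part of what the source reports. "The series", "measured", "known", "first", "only" and "open" are said of these compounds alone.

Compound 1 `N=C(N)c1ccc(-c2ccc(-c3cncc4ccccc34)s2)s1`: 1620 nM
Compound 2 `N=C(N)c1ccc(-c2ccc(-c3ccc(F)cc3)o2)o1`: 1650 nM

Of the compounds shown here, two have been measured in a functional assay on A549 cells (Homo sapiens) for inhibition, read by sulforhodamine B assay, with a stated time of 48 h; a higher number here means a weaker inhibitor of growth, a lower number a stronger inhibitor of growth. Compound 1 gives 1620 nM, and compound 2 gives 1650 nM; the two numbers sit within the usual scatter of each other, so neither can be called the stronger inhibitor of growth.

Compound 3 `N=C(N)c1ccc(-c2ccc(-c3ccc(Cl)cc3)o2)o1` is not yet measured. It differs from compound 2 in one place: chloro in place of fluoro on an aromatic carbon. Among the compounds with values here, no pair of measured compounds shows the effect of such a swap here, so there is nothing to anchor the size of the step.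

Given that, the value of compound 3 in this assay is expected to stay close to that of compound 2, since compound 2 gives 1650 nM and the change is small. The step from compound 2 to compound 3 is estimated as a 1.2-fold lower number from compound 2 to compound 3 (0.07 log units; within the scatter), likely within the scatter. The estimate for compound 3 is 1400 nM, with a range from 600 nM to 3300 nM.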

Compound 3, concentration for 50% growth inhibition: 1980 nM
Estimate against measurement, compound 3: 1.4-fold (0.15 log units) below, within the range that was stated.
By their numbers in this assay, from the lowest: compounds 1, 2 and 3 (each within the scatter of the next).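

In this assay, within the data shown here, the first pair of compounds differing in one place gives a 1.2-fold higher number from compound 2 to compound 3 (0.08 log units; within the scatter), so chloro in place of fluoro on an aromatic carbon, para to a large group, produces no difference that can be read. At this position on the shared core, the two halogens therefore cannot be told apart in this assay, which compounds 1 and 2 alone could not show. Nothing measured here gives a reason for this result, and no other data on these compounds bear on it.

The compounds shown leave open whether a very different group at the same position, such as an amine or a carboxylic acid, would give a step beyond the scatter. They also leave open whether the same swap would read alike on a different core.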